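The compounds below may be only part of what the source reports. "The series", "measured", "known", "first", "only" and "open" are said of these compounds alone.

Compound 1 `CCn1c(-c2ccc(OCc3c(-c4c(Cl)cccc4Cl)noc3C(C)C)cc2)nc2ccc(C(=O)O)cc21` gives 2.31 nM in an assay on Huh-7 cells for agonist activity at Bile acid receptor (Homo sapiens), read by a luciferase reporter; a higher number here means that more compound is needed for the effect, a lower number that less compound is needed. Within the data shown here, compound 2 `CC(C)c1onc(-c2c(Cl)cccc2Cl)c1COc1ccc(-c2nc3ccc(C(=O)O)cc3n2CC2CC2)cc1` gives 19.4 nM in this assay, the highest of the two numbers so far, and the one measured step is an 8.4-fold higher number from compound 1 to compound 2 (0.92 log units; beyond the scatter). Compound 3 `CC(C)Cn1c(-c2ccc(OCc3c(-c4c(Cl)cccc4Cl)noc3C(C)C)cc2)nc2ccc(C(=O)O)cc21` carries isopropyl in place of cyclopropyl on a saturated chain carbon bound to an aromatic nitrogen. Among the measured compounds shown here, only that step, cyclopropyl in place of methyl on the same carbon, bears on this change; it was modest. Swapping one three-carbon group for another is expected to move the number less, probably within the scatter, so for compound 3 the expected step is a 1.3-fold lower number from compound 2 to compound 3 (0.11 log units; within the scatter). Compound 3 is estimated at 15 nM in this assay, ranging from 6 nM to 45 nM.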

Compound 3, half-maximal effective concentration: 5.26 nM
The estimate for compound 3 lay 2.9-fold (0.46 log units) above the measured number; measured number outside the range, below it.
By their numbers in this assay, from the lowest: compound 1; then compound 3; then compound 2.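

At the saturated chain carbon bound to an aromatic nitrogen, cyclopropyl and isopropyl are not interchangeable in this assay despite the same count of heavy atoms: the change gives a 3.7-fold lower number from compound 2 to compound 3 (0.57 log units; beyond the scatter) and so the presence of the ring matters at this position. Isopropyl still trails methyl, with a 2.3-fold higher number from compound 1 to compound 3 (0.36 log units; beyond the scatter) as the step, so heavy-atom count alone does not order these three groups. No measurement at hand accounts for the gap between cyclopropyl and isopropyl. As far as these compounds go, whether a longer straight chain such as n-propyl, or an amine, at this carbon would fall nearer to compound 1 or to compound 2 remains open.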